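This account rests on a few compounds, and the source may have more. Where it says the series, first, only, none or still open, it means among the compounds named here.

Series notes, protein kinase C theta.

Of the compounds shown here, three have numbers so far. Compound 1 `N#Cc1cnc(NCc2ccccc2C(F)(F)F)cc1N[C@H]1CC[C@H](O)CC1` gives 4000 nM in an assay on isolated protein for inhibition of protein kinase C theta type (Homo sapiens), read by TR-FRET, with a stated time of 2 h; on this read-out lower numbers stand for stronger inhibition and higher numbers for weaker inhibition. Compound 2 `N#Cc1cnc(NCc2cnccc2C(F)(F)F)cc1NC[C@H]1CC[C@@H](O)CC1` gives 58 nM in this assay, and compound 3 `N#Cc1cnc(NCc2cnccc2C(F)(F)F)cc1N[C@H]1CC[C@@H](c2nc[nH]n2)CC1` gives 34 nM in this assay. Compound 2 thus stands second highest of the three; its number sits within the scatter of that of compound 3 and well beyond the scatter of that of compound 1.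

Compound 4 `CC1(C)C[C@@H](Nc2cc(NCc3cnccc3C(F)(F)F)ncc2C#N)CC[C@H]1O` is not yet measured. It differs from compound 2 in one place: 4-hydroxy-3,3-dimethylcyclohexyl in place of (4-hydroxycyclohexyl)methyl on a nitrogen on an aromatic ring. Compounds 1 and 3 carry the ring directly on that nitrogen and differ from compound 2 in more than one place, so no single shown step reads across to this change. The expectation is no step beyond the scatter, or at most a modest rise. For compound 4 the expected value in this assay is 80 nM, range 25 nM to 250 nM. The expected step is a 1.4-fold higher number from compound 2 to compound 4 (0.14 log units; within the scatter).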

Compound 4, half-maximal inhibitory concentration: 120 nM
Estimate against measurement, compound 4: 1.5-fold (0.18 log units) below, within the range that was stated.
By their numbers in this assay, from the lowest: compounds 3 and 2 (each within the scatter of the next); then compound 4; then compound 1.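

In this assay, among these compounds, the first single-place step at this position, a 2.1-fold higher number from compound 2 to compound 4 (0.32 log units; beyond the scatter), is modest but beyond the scatter. The position therefore responds to this change, though 4-hydroxy-3,3-dimethylcyclohexyl on the nitrogen costs little against (4-hydroxycyclohexyl)methyl. No measurement at hand bears on the reason for the rise.

The step changes both the attachment to the nitrogen and the ring substitution, and the compounds shown do not separate the two. From the compounds shown here alone, how an amine or a carboxylic acid in place of the hydroxyl on the 3,3-dimethylcyclohexyl ring would read also remains open.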